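From Isopropyl to Methyl on an Aromatic Ether Oxygen

This account rests on a few compounds, and the source may have more. Where it says the series, first, only, none or still open, it means among the compounds named here.

Measured so far:
compound 1 `CC(C)Oc1cncc(C2=CC3CNCC(C2)C3)c1`: 160%
compound 2 `CN1CC2C=C(c3ccc(F)nc3)CC(C2)C1`: 25%

In an in vitro functional assay on SH-SY5Y cells for agonist activity at Neuronal acetylcholine receptor; alpha3/beta4 (Homo sapiens), read by FLIPR and calcium flux (on this read-out higher numbers stand for larger maximal responses and lower numbers for smaller maximal responses), compound 1 gives the higher of the two numbers, and compound 2 gives a maximal response that lies lower by an amount beyond the usual scatter. Compound 3 `COc1cncc(C2=CC3CNCC(C2)C3)c1` differs from compound 1 by methyl in place of isopropyl on an oxygen on an aromatic ring. Within the data shown here, no measured pair shows this change, so the data offer no direct guide; a modest shift in this assay in either direction, or none beyond the scatter, is expected. For compound 3 the estimate in this assay is 130%, within 70% to 180%, which corresponds to an expected step of a number 30 percentage points lower from compound 1 to compound 3 (beyond the scatter).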

Compound 3, largest response reached (reported as percent of maximum), in percent of the reference or control that the assay uses: 145%
Compound 3: the middle estimate sits 15 percentage points below what was measured; measured number inside the range.
By their numbers in this assay, from the lowest: compound 2; then compound 3; then compound 1.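

In this assay, among these compounds, changing isopropoxy to methoxy on the shared core gives a number 15 percentage points lower from compound 1 to compound 3 (beyond the scatter) as the only direct reading of this change. With methyl in place of isopropyl on an oxygen on an aromatic ring, compound 3 still reaches 145% so isopropyl is not needed for a high maximal response in this pair. No measurement here accounts for the size of this step.

On these data alone, what an ethyl group or a longer chain on this oxygen would give in this assay stays open. So does whether an amine in place of the ether would keep such a response.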